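Shortening the thioether chain: pentenyl to propargyl

A few compounds are considered here, and "the series" means these few. Any claim that something is new, unique, unknown or untested is made for them only; others in the source may bear on it.

Two compounds have so far been measured in an assay on RAW264.7 cells for antagonist activity at Toll-like receptor 2 (Mus musculus), read by Griess assay, with a stated time of 24 h; on this read-out lower numbers stand for stronger inhibition and higher numbers for weaker inhibition:

Compound 1, `C#CCSC[C@H](NC(=O)c1cc(O)c(O)c(O)c1)C(=O)OC`: 71500 nM
Compound 2, `C=CCCCSC[C@H](NC(=O)c1cc(O)cc(O)c1)C(=O)OC`: 57800 nM

Compound 2 has the lower of the two numbers, yet its gap to compound 1 lies within the usual scatter, so the two count as alike.

Compound 3, `C#CCSC[C@H](NC(=O)c1cc(O)cc(O)c1)C(=O)OC`, is compound 2 with ethynyl in place of but-3-en-1-yl on a saturated chain carbon bound to a sulfur. Within the data shown here, no measured pair isolates this change: compound 1 carries the propargyl group but on a different core. The expectation is therefore a step from compound 2 to compound 3 of a 1.1-fold higher number from compound 2 to compound 3 (0.05 log units; within the scatter), not beyond the scatter. For compound 3 the estimated value is 65000 nM, with a range from 25000 nM to 160000 nM.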

Compound 3, half-maximal inhibitory concentration: 41800 nM
The estimate for compound 3 lay 1.6-fold (0.19 log units) above the measured number; the range from low to high includes it.
By their numbers in this assay, from the lowest: compounds 3, 2 and 1 (each within the scatter of the next).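

In this assay, among these compounds, the first pair that isolates the chain shows a 1.4-fold lower number from compound 2 to compound 3 (0.14 log units; within the scatter) for ethynyl in place of but-3-en-1-yl on a saturated chain carbon bound to a sulfur, so this shortening leaves the number within the scatter. Compound 1 and compound 3 now also isolate a change on the core, hydrogen in place of hydroxy on an aromatic carbon, and a 1.7-fold lower number from compound 1 to compound 3 (0.23 log units; within the scatter) again stays within the scatter. No measurement here explains either step. Still open, on these data alone, is whether an amine or a carboxylic acid on that same chain carbon would move the number beyond the scatter.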